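The source may hold more compounds than are shown below. What is called first, only, known or untested is meant among the compounds shown, and "the series" means these compounds.

Compound 1 `CS(=O)(=O)c1ccc(C(=O)NCCC(=O)N2CCCc3ccccc32)cc1[N+](=O)[O-]` was tested in an assay on isolated protein for inhibition of thyroid hormone receptor alpha (Homo sapiens), read by fluorescence polarization; on this read-out higher numbers stand for weaker inhibition and lower numbers for stronger inhibition. In this assay compound 1 gives > 60000 nM, which is a limit of the assay rather than a number. Compound 2 `CN(CC(=O)N1CCN(c2ccc(F)cc2)CC1)C(=O)c1ccc(S(C)(=O)=O)c([N+](=O)[O-])c1` also gives a limit in this assay, > 60000 nM. Compound 3 `CS(=O)(=O)c1ccc(C(=O)NCC(=O)N2CCN(c3ccccc3F)CC2)cc1[N+](=O)[O-]` likewise gives a limit, > 60000 nM. All three values sit at the same limit (the limit of > 60000 nM in this assay, at which 3 of the 3 values shown sit), so where compound 1 stands against the others cannot be told. Compound 4 `CC(C)N(C(=O)CCNC(=O)c1ccc(S(C)(=O)=O)c([N+](=O)[O-])c1)C(C)C` has not yet been measured. It differs from compound 1 by diisopropylamino in place of 1,2,3,4-tetrahydroquinolin-1-yl on a carbonyl carbon. Among the measured compounds shown here, no step between measured compounds is available, so no direction can be drawn from them. The step of a number no higher from compound 1 to compound 4 (the limit leaves the size open) is expected to be none beyond the scatter. The estimate for compound 4 is 60000 nM, within 20000 nM to 200000 nM.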

Compound 4, half-maximal inhibitory concentration: > 60000 nM
Compound 4: only a limit was reported; the forecaster's own chance of this, stated with the estimate: 85%; the middle value lies on the limit itself.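

No step can be read between compound 1 and compound 4, since both carry only a limit: the limit of > 60000 nM in this assay, at which 4 of the 4 values shown sit.

The compounds shown leave open how they rank against one another and which change would give a readable value in this assay.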